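This account rests on a few compounds, and the source may have more. Where it says the series, first, only, none or still open, it means among the compounds named here.

Compound 3 `COc1cc2ncnc(Nc3ccc(F)c(Cl)c3)c2cc1OCCn1c([N+](=O)[O-])cnc1C` is the weakest point among the three measured compounds: in a functional assay on HT-29 cells (Homo sapiens) for cytotoxicity, read by sulforhodamine B assay, with a stated time of 72 h (on this read-out higher numbers stand for weaker inhibition and lower numbers for stronger inhibition), compound 3 gives > 50000 nM, which is a limit of the assay rather than a number, and so sits at the limit of > 50000 nM in this assay, at which 1 of the 3 values shown sits. Compound 1 `COc1cc2ncnc(Nc3ccc(F)c(Cl)c3)c2cc1OCCCCn1ccnc1[N+](=O)[O-]` gives 1620 nM, while compound 2 `COc1cc2ncnc(Nc3ccc(F)c(Cl)c3)c2cc1OCCCCCn1ccnc1[N+](=O)[O-]` gives 5590 nM. The measured steps are a 3.5-fold higher number from compound 1 to compound 2 (0.54 log units; beyond the scatter), an at least 30-fold higher number from compound 1 to compound 3 (1.48 log units; beyond the scatter) and an at least 8.9-fold higher number from compound 2 to compound 3 (0.95 log units; beyond the scatter). Compound 4 `COc1cc2ncnc(Nc3ccc(F)c(Cl)c3)c2cc1OCCCCn1c([N+](=O)[O-])cnc1C` differs from compound 3 by 2-(2-methyl-5-nitro-1H-imidazol-1-yl)ethyl in place of 2-methyl-5-nitro-1H-imidazol-1-yl on a saturated chain carbon, two bonds along the chain from an oxygen on an aromatic ring. Within the data shown here, the only chain-lengthening step seen, a 3.5-fold higher number from compound 1 to compound 2 (0.54 log units; beyond the scatter), weakened inhibition, so a longer chain offers no ground to expect compound 4 to escape the limit. For compound 4 the expected result in this assay is 40000 nM, within 12000 nM to 150000 nM, an expected step of an at least 1.2-fold lower number from compound 3 to compound 4 (0.09 log units; that floor lies within the scatter).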

Compound 4, half-maximal inhibitory concentration: 9980 nM
Compound 4: middle estimate off by 4.0-fold (0.60 log units), on the high side, and the stated range ends above it.
By their numbers in this assay, from the lowest: compound 1; then compounds 2 and 4 (each within the scatter of the next). At a limit, above all of these: compound 3.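

Compound 3 remains a limit of the assay, not a number: the limit of > 50000 nM in this assay, at which 1 of the 4 values shown sits. In this assay, the longer chain still brings a readable value, an at least 5.0-fold lower number from compound 3 to compound 4 (0.69 log units; beyond the scatter), so chain length matters for the 2-methyl-5-nitro-1H-imidazol-1-yl group too, here in the opposite direction to a 3.5-fold higher number from compound 1 to compound 2 (0.54 log units; beyond the scatter). On the same chain, this group does worse than 2-nitro-1H-imidazol-1-yl, a 6.2-fold higher number from compound 1 to compound 4 (0.79 log units; beyond the scatter), while a 1.8-fold higher number from compound 2 to compound 4 (0.25 log units; within the scatter) leaves those two compounds unordered.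

As far as these compounds go, whether a still longer chain would carry the 2-methyl-5-nitro-1H-imidazol-1-yl group further remains open. So does the effect of an amine in place of the nitro group.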